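This account rests on a few compounds, and the source may have more. Where it says the series, first, only, none or still open, it means among the compounds named here.

Compounds measured in a functional assay on M21 cells (Homo sapiens) for antiproliferative activity, read by sulforhodamine B assay, with a stated time of 48 h; on this read-out lower numbers stand for stronger inhibition of growth and higher numbers for weaker inhibition of growth:

Compound 1, `CC(C)(C)c1ccc(-c2cc(N3CCC(CNS(N)(=O)=O)CC3)ncn2)cc1`: 19300 nM
Compound 2, `COc1ccc(-c2cc(N3CCC(CNS(N)(=O)=O)CC3)ncn2)cc1`: a limit of the assay, > 100000 nM
Compound 3, `COC(=O)c1ccc(-c2cc(N3CCC(CNS(N)(=O)=O)CC3)ncn2)cc1`: 14100 nM

For the measured compounds named here, compound 2 stands at the weak end of this set: its result is only a limit, (the limit of > 100000 nM in this assay, at which 1 of the 3 values shown sits), and it is the single compound of the three to sit there. The step of an at least 5.1-fold higher number from compound 1 to compound 2 (0.71 log units; beyond the scatter) and the step of an at least 7.0-fold lower number from compound 2 to compound 3 (0.85 log units; beyond the scatter) both run beyond the scatter, whereas the step of a 1.4-fold lower number from compound 1 to compound 3 (0.14 log units; within the scatter) stays within it.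

Compound 4, `COc1ccccc1-c1cc(N2CCC(CNS(N)(=O)=O)CC2)ncn1`, is not yet measured. It differs from compound 2 by 2-methoxyphenyl in place of 4-methoxyphenyl on an aromatic carbon. Going by the values given here, none of the measured steps bears directly on this change: each of them exchanges one group for another on the same aromatic carbon, and none shifts the methoxy group to a different position. The measured steps therefore give no direction for the move, and the expectation for compound 4 rests on compound 2 alone, whose value is a limit. The step of an at least 1.4-fold lower number from compound 2 to compound 4 (0.15 log units; that floor lies within the scatter) is thus estimated as small and uncertain, with a real chance that compound 4 again returns only a limit. Compound 4 is expected to give about 70000 nM in this assay, within a range from 15000 nM to 250000 nM.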

Compound 4, concentration for 50% growth inhibition: > 100000 nM
Compound 4 ended at the assay's limit; the forecaster's own chance of this, stated with the estimate: 50%; at least 1.4-fold (0.15 log units) between middle value and limit.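

In this assay compound 4 gives > 100000 nM, which is a limit of the assay, and the result for compound 2 is also only a limit, so no step between compound 2 and compound 4 can be read: the limit of > 100000 nM in this assay, at which 2 of the 4 values shown sit.

The compounds shown leave open whether 2-methoxyphenyl and 4-methoxyphenyl differ at all in their inhibition of growth.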